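Bromo in place of chloro: an expected small step

The source may report more compounds than this note shows. Statements on the series, on what has been measured and on what is new or still open speak of the compounds shown alone.

In a functional assay on HeLa cells (Homo sapiens) for cytotoxicity, read by MTT assay, with a stated time of 72 h (a lower number here means a stronger inhibitor, a higher number a weaker inhibitor), compound 1 (`Cn1ccc2c(Oc3ccc(NC(=O)c4cc5cccnc5n(-c5ccccc5)c4=O)cc3)ncnc21`) gives 59800 nM and compound 2 (`Cn1ccc2c(Oc3ccc(NC(=O)c4cc5cccnc5n(-c5ccc(Cl)cc5)c4=O)cc3)ncnc21`) gives 49900 nM as its number, so the two stand level within the scatter. Compound 3 (`Cn1ccc2c(Oc3ccc(NC(=O)c4cc5cccnc5n(-c5ccc(Br)cc5)c4=O)cc3)ncnc21`) carries bromo in place of chloro on an aromatic carbon. For the measured compounds named here, the one measured step that bears on this change is chloro in place of hydrogen on that same ring (a 1.2-fold lower number from compound 1 to compound 2 (0.08 log units; within the scatter)), which stayed within the scatter. So in this assay no shift beyond the scatter is expected (estimated a 1.1-fold lower number from compound 2 to compound 3 (0.04 log units; within the scatter)). For compound 3 the expected value is 46000 nM with an estimated range (22000 nM to 90000 nM).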

Compound 3, half-maximal inhibitory concentration: 43800 nM
For compound 3 the middle estimate is 1.1-fold (0.02 log units) above the measured one, and the stated range covers the measured number.
By their numbers in this assay, from the lowest: compounds 3, 2 and 1 (each within the scatter of the next).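

Bromo in place of chloro on this ring leaves the number within the scatter in this assay (a 1.1-fold lower number from compound 2 to compound 3 (0.06 log units; within the scatter)), and so does bromo in place of hydrogen (a 1.4-fold lower number from compound 1 to compound 3 (0.14 log units; within the scatter)). Compound 3 therefore adds a second halogen at this place, para to a large group, and neither halogen separates from the unsubstituted compound 1. Nothing measured here offers an explanation for these small steps. Still open, as far as these compounds go, is whether a fluoro group, an amine or a carboxylic acid at this place would move the number beyond the scatter.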